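Fluorine position on the benzyl group and growth inhibition

This account rests on a few compounds, and the source may have more. Where it says the series, first, only, none or still open, it means among the compounds named here.

Compound 1 `O=C(/C=C/c1ccc(OCc2cn(Cc3ccccc3F)nn2)cc1)c1ccc(Br)cc1` and compound 2 `O=C(/C=C/c1ccc(OCc2cn(Cc3cccc(F)c3)nn2)cc1)c1ccc(Br)cc1` share one core, while compound 3 `O=C(/C=C/c1ccc(OCc2cn(Cc3ccccc3F)nn2)cc1)c1ccc([N+](=O)[O-])cc1` and compound 4 `O=C(/C=C/c1ccc(OCc2cn(Cc3cccc(F)c3)nn2)cc1)c1ccc([N+](=O)[O-])cc1` share another; the two cores differ by nitro in place of bromo on an aromatic carbon. In a functional assay on HepG2 cells (Homo sapiens) for inhibition, read by MTT assay, with a stated time of 48 h, tested at 10 uM (on this read-out higher numbers stand for more inhibition of growth at the one concentration tested and lower numbers for less inhibition of growth), compound 1 gives 29%, compound 2 gives 34% and compound 3 gives 22%. The change from compound 1 to compound 2 is 3-fluorophenyl in place of 2-fluorophenyl on a saturated chain carbon bound to an aromatic nitrogen, and it made a number 5 percentage points higher from compound 1 to compound 2 (within the scatter). Between the two cores the exchange made a number 7 percentage points lower from compound 1 to compound 3 (within the scatter). Compound 4 has not yet been measured in this assay; it differs from compound 3 by 3-fluorophenyl in place of 2-fluorophenyl on a saturated chain carbon bound to an aromatic nitrogen, the same change at the same place as that from compound 1 to compound 2. Only this one earlier occurrence of the change is available, and it did not leave the scatter. Because the earlier change made a number 5 percentage points higher from compound 1 to compound 2 (within the scatter), the step expected for compound 4 is a number 5 percentage points higher from compound 3 to compound 4 (within the scatter). Compound 4 is therefore estimated at 27%, most likely falling between 14% and 40%.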

Compound 4, percent growth inhibition at one concentration: 43%
Estimate against measurement, compound 4: 16 percentage points below, outside the stated range (above it).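

In this assay, the exchange of 2-fluorobenzyl for 3-fluorobenzyl gave a number 21 percentage points higher from compound 3 to compound 4 (beyond the scatter), and the size of this step did not carry over from the core of compound 1 to the core of compound 3: the same change on two cores in this assay, a number 5 percentage points higher (within the scatter) from compound 1 to compound 2 and a number 21 percentage points higher (beyond the scatter) from compound 3 to compound 4, 16 percentage points apart, beyond the scatter of two such steps. The exchange of bromo for nitro gave a number 9 percentage points higher from compound 2 to compound 4 (within the scatter), and this step also differed with the benzyl group present: the same change on two cores in this assay, a number 7 percentage points lower (within the scatter) from compound 1 to compound 3 and a number 9 percentage points higher (within the scatter) from compound 2 to compound 4, 16 percentage points apart, beyond the scatter of two such steps. This shows that, among these four compounds, the step seen on one core could not simply be transferred to the other, but two pairs at one tested concentration give no general rule and do not show why the steps differ.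

The compounds shown leave open whether the same holds for a plain benzyl or a chlorobenzyl group on the triazole nitrogen. They also leave open how either benzyl group would behave with an amine or a methoxy group in place of bromo or nitro.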